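The source may hold more compounds than are shown below. What is called first, only, known or untested is meant among the compounds shown, and "the series" means these compounds.

Three compounds share one core and differ only in the group carried on the ring nitrogen's attached phenyl. Compound 1 `COc1ccc(S(=O)(=O)c2nc3ccccc3nc2Nc2ccccc2)cc1` gives 1260 nM in a functional assay on PC-3 cells (Homo sapiens) for cytotoxicity, read by MTT assay, with a stated time of 72 h; a higher number here means a weaker inhibitor, a lower number a stronger inhibitor. Compound 2 `COc1ccc(S(=O)(=O)c2nc3ccccc3nc2Nc2cc(OC)cc(OC)c2)cc1` gives 6220 nM in this assay, and compound 3 `COc1ccc(S(=O)(=O)c2nc3ccccc3nc2Nc2ccc(N)cc2)cc1` gives 9640 nM in this assay. Compound 3 shows the highest number as measured, yet its gap to compound 2 is within the scatter, so the two are not told apart, whereas a 7.7-fold higher number from compound 1 to compound 3 (0.88 log units; beyond the scatter) lies beyond it. Compound 4 `COc1ccc(S(=O)(=O)c2nc3ccccc3nc2Nc2ccc(F)cc2)cc1` differs from compound 3 by fluoro in place of amino on an aromatic carbon. Going by the values given here, the only measured step at the same place is a 7.7-fold higher number from compound 1 to compound 3 (0.88 log units; beyond the scatter), which added the amino and raised the number. Removing it is therefore expected to lower the number, though fluoro is not hydrogen, so the expected step is a 4.4-fold lower number from compound 3 to compound 4 (0.64 log units; beyond the scatter). Compound 4 is expected to give about 2200 nM, between 800 nM and 6500 nM.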

Compound 4, half-maximal inhibitory concentration: 2200 nM
Estimate against measurement, compound 4: no gap at the digits printed, within the range that was stated.
By their numbers in this assay, from the lowest: compounds 1 and 4 (each within the scatter of the next); then compounds 2 and 3 (each within the scatter of the next).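

Amino is not the only group that can sit at this position, and the number depends on which group is there: in this assay the change shows a 4.4-fold lower number from compound 3 to compound 4 (0.64 log units; beyond the scatter) when fluoro replaces amino. Fluoro in place of hydrogen gives a 1.7-fold higher number from compound 1 to compound 4 (0.24 log units; within the scatter) and so leaves that pair not told apart, while a 2.8-fold lower number from compound 2 to compound 4 (0.45 log units; beyond the scatter) separates the 4-fluorophenyl group from the 3,5-dimethoxyphenyl group. Nothing measured here accounts for these differences. As far as these compounds go, whether a chloro, hydroxyl or carboxylic acid group at the same place would stay close to hydrogen and fluoro or move toward amino remains open. The same applies to fluoro placed elsewhere on this ring.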